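A few compounds are considered here, and "the series" means these few. Any claim that something is new, unique, unknown or untested is made for them only; others in the source may bear on it.

Going by the values given here, only two compounds have numbers so far. In a functional assay on A549 cells (Homo sapiens) for cytotoxicity, read by MTT assay, with a stated time of 72 h (on this read-out higher numbers stand for an effect only at larger amounts of compound and lower numbers for an effect already at smaller amounts), compound 1 `CCc1cccc2c(O)c(-c3occ(C)c3C(=O)O)ccc12` gives 10.6 ug/mL and compound 2 `CCOC(=O)c1c(C)coc1-c1ccc2c(CC)cccc2c1OC` gives 3.8 ug/mL as the lower of the two numbers. Compound 2 therefore shows its effect at the smaller amount, and the gap between the two lies beyond the usual scatter of repeated measurements.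

Compound 3 `CCc1cccc2c(OC)c(-c3occ(C)c3C(=O)NC)ccc12` is still unmeasured. It keeps the core of compound 2 and changes one place: methylamino in place of ethoxy on a carbonyl carbon, so an ethoxycarbonyl becomes a methylcarbamoyl (methylamino in place of ethoxy on a carbonyl carbon). Among the compounds with values here, no measured pair shows this change alone, so the data do not give its size directly. Within the data shown here, compound 1 at 10.6 ug/mL is the only guide to how far numbers in this assay may move from compound 2. A modest shift toward a higher number seems likely, though it may stay within the scatter. The expected change is the estimated 1.8-fold higher number from compound 2 to compound 3 (0.27 log units; within the scatter) in this assay for now. For compound 3 the estimated value is 7 ug/mL with a range from 3 ug/mL to 18 ug/mL as the likely span.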

Compound 3, concentration for half-maximal effect: > 10 ug/mL
Compound 3 was reported as a limit (the forecaster's own chance of this, stated with the estimate: 5%); at least 1.4-fold (0.15 log units) between middle value and limit.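

Compound 3 gives > 10 ug/mL in this assay, and this value is a limit of the assay, not a number. Placing methylamino in place of ethoxy on a carbonyl carbon, so that ethoxycarbonyl becomes methylcarbamoyl, gives an at least 2.6-fold higher number from compound 2 to compound 3 (0.42 log units; beyond the scatter) in this assay, which is the first reading of a change in one place in this series and shows that the group on this carbonyl carbon matters for the read-out. Only the lower end of this step is known, and its full size cannot be read because compound 3 stands at a limit: the limit of > 10 ug/mL in this assay, at which 1 of the 3 values shown sits.

The compounds shown leave open which part of the change carries the step, since ethoxy and methylamino differ in more than one way, including the donor and acceptor counts and the size of the group. An ethylamino or a dimethylamino group on the same carbonyl carbon, or a longer chain such as propoxy, would be needed to separate these differences.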